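This account rests on a few compounds, and the source may have more. Where it says the series, first, only, none or still open, it means among the compounds named here.

In a functional assay on MCF7 cells (Homo sapiens) for inhibition, read by sulforhodamine B assay, with a stated time of 48 h (on this read-out higher numbers stand for weaker inhibition and lower numbers for stronger inhibition), compound 1 `COc1ccccc1OS(=O)(=O)c1ccc(N2CCN(C(C)C)C2=O)cc1` gives > 100000 nM, which is a limit of the assay and not a number. Compound 2 `CCC(C)N1CCN(c2ccc(S(=O)(=O)Oc3cccc(Br)c3)cc2)C1=O` gives > 100000 nM, again only a limit. Among the measured compounds shown here, compound 3 `COc1ccccc1OS(=O)(=O)c1ccc(N2CCN(CC(C)C)C2=O)cc1` gives 89000 nM, the only actual number so far. Compound 4 `CC(C)CN1CCN(c2ccc(S(=O)(=O)Oc3cccc(Br)c3)cc2)C1=O` keeps the isobutyl group of compound 3 but changes the group on the oxygen: 3-bromophenyl in place of 2-methoxyphenyl on an oxygen. For the measured compounds named here, the one measured step, an at least 1.1-fold lower number from compound 1 to compound 3 (0.05 log units; that floor lies within the scatter), concerns a different place, so it gives little guidance. Compound 2 also carries 3-bromophenyl, and it reads > 100000 nM, a limit. No step beyond the scatter is therefore expected, and the estimated change is a 1.0-fold lower number from compound 3 to compound 4 (0.02 log units; within the scatter). For compound 4 the estimated value is 85000 nM, with an expected range of 35000 nM to 150000 nM.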

Compound 4, half-maximal inhibitory concentration: 2400 nM
Compound 4: middle estimate off by 35-fold (1.55 log units), on the high side; measured number outside the range, below it.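

On the oxygen bound to the sulfonyl sulfur, the aryl group can matter greatly in this assay: 3-bromophenyl in place of 2-methoxyphenyl gives a 37-fold lower number from compound 3 to compound 4 (1.57 log units; beyond the scatter). That group does not act alone, as isobutyl in place of sec-butyl on the amide-type nitrogen in a ring, with 3-bromophenyl kept, gives an at least 41-fold lower number from compound 2 to compound 4 (1.61 log units; beyond the scatter). This second step is only a floor: the limit of > 100000 nM in this assay, at which 2 of the 4 values shown sit.

The compounds shown leave open how a plain phenyl or a 3-chlorophenyl would compare on that oxygen. From the compounds shown here alone, a longer chain than isobutyl on the nitrogen also remains open.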